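Moving the fluorine on the benzyl amide

A few compounds are considered here, and "the series" means these few. Any claim that something is new, unique, unknown or untested is made for them only; others in the source may bear on it.

Measured so far:
compound 1 `Cc1cccc(Cc2n[nH]c3cc(O)c(C(=O)NCc4ccccc4)cc23)c1`: > 10000 nM (a limit)
compound 2 `Cc1cccc(Cc2n[nH]c3cc(O)c(C(=O)N(C)Cc4cccc(F)c4)cc23)c1`: 440 nM

Going by the values given here, in a functional assay on A2780 cells (Homo sapiens) for antiproliferative activity, read by resazurin assay, with a stated time of 72 h (on this read-out higher numbers stand for weaker inhibition and lower numbers for stronger inhibition), compound 2 gives 440 nM, the only actual number so far. Compound 1 reaches only a limit of the assay, > 10000 nM.

The next compound is compound 3 `Cc1cccc(Cc2n[nH]c3cc(O)c(C(=O)N(C)Cc4ccc(F)cc4)cc23)c1`. The change is 4-fluorophenyl in place of 3-fluorophenyl on a saturated chain carbon bound to an amide-type nitrogen.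

Among the compounds with values here, only one measured step bears on this. The step of an at least 22-fold lower number from compound 1 to compound 2 (1.35 log units; beyond the scatter) is large, but it replaces the whole benzylamino group with (3-fluorobenzyl)(methyl)amino, so it does not isolate where the fluorine sits. Within the data shown here, no measured pair moves the fluorine alone. In this assay a step beyond the scatter is therefore not expected, and no direction is favoured, though the uncertainty is wide.

For compound 3 the estimated value is 500 nM, with an expected range of 150 nM to 1800 nM. The expected step is a 1.1-fold higher number from compound 2 to compound 3 (0.06 log units; within the scatter).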

Compound 3, half-maximal inhibitory concentration: 590 nM
Beside the measured number, compound 3's estimate is 1.2-fold (0.07 log units) below it; the range from low to high includes it.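

In this assay, moving the fluorine from 3-fluorophenyl to 4-fluorophenyl on the saturated chain carbon bound to an amide-type nitrogen gives a 1.3-fold higher number from compound 2 to compound 3 (0.13 log units; within the scatter), so the two fluorine placements cannot be told apart in this pair. The large change from the secondary benzyl amide therefore holds for both fluorobenzyl groups, with an at least 16-fold lower number from compound 1 to compound 3 (1.22 log units; beyond the scatter) standing alongside an at least 22-fold lower number from compound 1 to compound 2 (1.35 log units; beyond the scatter), and it is not tied to 3-fluorophenyl alone. The size of both steps rests on a limit, that of compound 1, so each gives only a minimum for the change: the limit of > 10000 nM in this assay, at which 1 of the 3 values shown sits.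

The compounds shown do not separate the methyl on the amide nitrogen from the fluorine, since both change together in each step away from compound 1, so the share of each in the large change remains open. As far as these compounds go, how a chlorine atom or a nitrile in place of the fluorine, or a phenethyl group in place of the benzyl, would read in this assay also stays open.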